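Compound 3 and a dimethylated successor

This account rests on a few compounds, and the source may have more. Where it says the series, first, only, none or still open, it means among the compounds named here.

Values in a functional assay on A549 cells (Homo sapiens) for antiproliferative activity, read by MTT assay, with a stated time of 48 h (a lower number here means a stronger inhibitor, a higher number a weaker inhibitor), are as follows.

Compound 1 `COc1ccc(/C=C/c2cc(OC)cc(OC)c2/C=C/C(=O)c2cccc(OC)c2)cc1` gives 6.1 ug/mL in this test
Compound 2 `COc1ccc(/C=C/c2cc(OC)cc(OC)c2/C=C/C(=O)c2ccc(C(F)(F)F)cc2)cc1` gives 7.8 ug/mL in this test
Compound 3 `COc1ccc(/C=C/c2cc(OC)cc(OC)c2/C=C/C(=O)c2ccccc2)cc1` gives 3.9 ug/mL in this test

On these numbers, compound 3 cannot be separated from the other two compounds. The measured 1.6-fold lower number from compound 1 to compound 3 (0.19 log units; within the scatter) and a 2.0-fold lower number from compound 2 to compound 3 (0.30 log units; within the scatter) both lie within the scatter, as does a 1.3-fold higher number from compound 1 to compound 2 (0.11 log units; within the scatter) between the two compounds with a substituted ring.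

Compound 4 `COc1ccc(/C=C/c2cc(OC)cc(OC)c2/C=C/C(=O)c2ccc(C)cc2C)cc1` has 2,4-dimethylphenyl in place of phenyl on a carbonyl carbon. Within the data shown here, no measured compound carries this group, so the evidence is indirect. The closest guide is the pair of steps from compound 1 and compound 2 to compound 3, each of which removes a single group from an aromatic carbon. Neither goes beyond the scatter, so no step beyond the scatter is expected in this assay for the new change. Among the measured compounds shown here, this rests on only three compounds, and none of them shows what two methyl groups on that ring would do.

The estimate amounts to a 1.3-fold higher number from compound 3 to compound 4 (0.12 log units; within the scatter) and is expected to stay within the scatter. For compound 4 the estimated value is 5.2 ug/mL with an expected range from 2.8 ug/mL to 10 ug/mL in this test.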

Compound 4, half-maximal inhibitory concentration: 0.3 ug/mL
The estimate for compound 4 lay 17-fold (1.24 log units) above the measured number; measured number outside the range, below it.
By their numbers in this assay, from the lowest: compound 4; then compounds 3, 1 and 2 (each within the scatter of the next).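

In this assay the aryl group on the carbonyl carbon proves able to move the number well beyond the scatter: 2,4-dimethylphenyl in place of phenyl gives a 13-fold lower number from compound 3 to compound 4 (1.11 log units; beyond the scatter) and thereby does what none of the earlier changes on that ring did. Among these compounds, the same group also stands clear of both compounds with a substituted ring, with a 20-fold lower number from compound 1 to compound 4 (1.31 log units; beyond the scatter) and a 26-fold lower number from compound 2 to compound 4 (1.41 log units; beyond the scatter) as the other two steps, so compound 4 is the one compound of the four separated from all the others, and it is the strongest of them. Nothing available here bears on the reason for this large difference.

Since the two methyl groups enter together, the compounds shown do not tell whether a single methyl group on that ring would give a step of this size or whether both are needed. They also leave open what an ethyl group, a chlorine atom or an amine on that ring would do in this assay and whether any of these would match compound 4.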